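This account rests on a few compounds, and the source may have more. Where it says the series, first, only, none or still open, it means among the compounds named here.

Working notes on the series in an ADME assay on Huh-7 cells (Homo sapiens) for cytotoxicity; a higher number here means that more compound is tolerated, a lower number that less compound is tolerated. Compound 1 `Cc1ccccc1-c1nn(-c2ccc(F)cc2F)cc1CN1CCN(c2ccccc2)CC1` reaches only a limit of > 20000 nM; this is the limit of > 20000 nM in this assay, at which 1 of the 3 values shown sits. Compound 2 `Cc1ccccc1-c1nn(-c2ccc(Cl)cc2)cc1CNCCN1CCN(C)CC1` gives 17000 nM, the higher of the two plain numbers, while compound 3 `CN1CCN(CCCNCc2cn(-c3ccc([N+](=O)[O-])cc3)nc2-c2ccc(Cl)cc2)CC1` gives 3700 nM, a gap beyond the scatter. Compound 4 `Cc1ccccc1-c1nn(-c2ccc(F)cc2F)cc1CNCCN1CCN(C)CC1` has not been measured. It differs from compound 2 by 2,4-difluorophenyl in place of 4-chlorophenyl on an aromatic nitrogen. Compound 1 carries the same 2,4-difluorophenyl on the same aromatic nitrogen and sits at the limit of > 20000 nM, so no step beyond the scatter is expected here. The change from compound 2 to compound 4 is estimated at a 1.2-fold higher number from compound 2 to compound 4 (0.07 log units; within the scatter). Compound 4 is expected to give 20000 nM, with a range from 9000 nM to 40000 nM.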

Compound 4, half-maximal cytotoxic concentration: > 20000 nM
Compound 4: no number, only a limit (the forecaster's own chance of this, stated with the estimate: 45%); the middle value sits exactly at the limit.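

In this assay, among these compounds, 2,4-difluorophenyl in place of 4-chlorophenyl on the aromatic nitrogen gives an at least 1.1-fold higher number from compound 2 to compound 4 (0.07 log units; that floor lies within the scatter), the first direct reading of a change at this position. Among the compounds shown here, that step is only a floor, so the change shows no loss of tolerated compound, but its true size stays unread. Compound 4 gives a limit, not a number, and it joins compound 1 there: the limit of > 20000 nM in this assay, at which 2 of the 4 values shown sit.

As far as these compounds go, whether a larger step lies hidden behind that limit remains open. Also open, from the compounds shown here alone, is how an unsubstituted phenyl or a pyridyl group on this nitrogen would read.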